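Piperidin-1-yl for diisopropylamino: working notes on compound 4

A few compounds are considered here, and "the series" means these few. Any claim that something is new, unique, unknown or untested is made for them only; others in the source may bear on it.

In a functional assay on PC-3 cells (Homo sapiens) for cytotoxicity, read by MTT assay, with stated times of 48 h and 4 h (a lower number here means a stronger inhibitor, a higher number a weaker inhibitor), compound 1 `COc1ccc(/C=C/c2nc(NCCN3CCCCC3)c3cc(Cl)ccc3n2)cc1OC` gives 21200 nM and compound 2 `O=[N+]([O-])c1ccc(/C=C/c2nc(NCCN3CCCCC3)c3ccccc3n2)cc1` gives 25600 nM. Compound 3 `CC(C)N(CCNc1nc(/C=C/c2ccc([N+](=O)[O-])cc2)nc2ccc(Cl)cc12)C(C)C` reads > 100000 nM, which is a limit of the assay and not a number. Compound 4 `O=[N+]([O-])c1ccc(/C=C/c2nc(NCCN3CCCCC3)c3cc(Cl)ccc3n2)cc1` has not been measured. It differs from compound 3 at one place: piperidin-1-yl in place of diisopropylamino on a saturated chain carbon, two bonds along the chain from a nitrogen on an aromatic ring, with piperidin-1-yl in place of diisopropylamino on a saturated chain carbon, two bonds along the chain from a nitrogen on an aromatic ring. Compound 1 at 21200 nM and compound 2 at 25600 nM both carry piperidin-1-yl, so a measured number in that same region is expected. A clear gain in this assay is therefore expected, with an estimated at least 4.5-fold lower number from compound 3 to compound 4 (0.65 log units; beyond the scatter). For compound 4 the estimated value is 22000 nM, within an expected range of 9000 nM to 60000 nM.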

Compound 4, half-maximal inhibitory concentration: > 100000 nM
Compound 4 was reported as a limit; the forecaster's own chance of this, stated with the estimate: 8%; at least 4.5-fold (0.65 log units) between middle value and limit.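

In this assay compound 4 reads > 100000 nM, a limit of the assay and not a number, so piperidin-1-yl at this place does not by itself give a measured value. The step from diisopropylamino to piperidin-1-yl cannot be read, because compound 3 and compound 4 both sit at the limit: the limit of > 100000 nM in this assay, at which 2 of the 4 values shown sit.

Within the piperidin-1-yl compounds, chloro in place of hydrogen gives an at least 3.9-fold higher number from compound 2 to compound 4 (0.59 log units; beyond the scatter), and 4-nitrophenyl in place of 3,4-dimethoxyphenyl gives an at least 4.7-fold higher number from compound 1 to compound 4 (0.67 log units; beyond the scatter); the two groups together go with the loss.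

Still open, from the compounds shown here alone, is whether morpholin-4-yl or dimethylamino at this place, with chloro and 4-nitrophenyl kept, would give a measured value.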